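Rearranging halogens on the sulfonamide aryl of compound 3

This account rests on a few compounds, and the source may have more. Where it says the series, first, only, none or still open, it means among the compounds named here.

Of the compounds shown here, three sharing one core have been measured in an assay on isolated protein for binding affinity to 5-hydroxytryptamine receptor 6 (Homo sapiens); on this read-out lower numbers stand for stronger inhibition and higher numbers for weaker inhibition. Compound 1 `COc1ccc(S(=O)(=O)Nc2ccc(C)cc2Br)cc1N1CCNCC1` gives 7.94 nM. Compound 2 `COc1ccc(S(=O)(=O)Nc2cc(Cl)c(Cl)cc2Cl)cc1N1CCNCC1` gives 5.01 nM, and the change a 1.6-fold lower number from compound 1 to compound 2 (0.20 log units; within the scatter) stays within the scatter. Compound 3 `COc1ccc(S(=O)(=O)Nc2cc(Cl)cc(Br)c2Cl)cc1N1CCNCC1` gives 2 nM, the lowest of the three numbers: its steps of a 4.0-fold lower number from compound 1 to compound 3 (0.60 log units; beyond the scatter) and a 2.5-fold lower number from compound 2 to compound 3 (0.40 log units; beyond the scatter) both lie beyond the scatter, so compound 3 is the most potent measured here.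

Compound 4 `COc1ccc(S(=O)(=O)Nc2cc(Br)cc(Cl)c2Cl)cc1N1CCNCC1` is built from compound 3 by 5-bromo-2,3-dichlorophenyl in place of 3-bromo-2,5-dichlorophenyl on a sulfonamide nitrogen. The bearing steps are those that rework the aryl on the sulfonamide nitrogen; the closest is the rearrangement of halogens from compound 2 to compound 3, which was modest, and the larger step from compound 1 to compound 3 also only modest. Since compound 4 keeps the same atoms, only shuffled, the expected step in this assay, a 1.8-fold higher number from compound 3 to compound 4 (0.24 log units; within the scatter), is small, most likely a slightly higher number and possibly within the scatter. Compound 4 is therefore expected to give about 3.5 nM, in the range 1.5 nM to 9 nM.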

Compound 4, inhibition constant: 3.98 nM
Estimate against measurement, compound 4: 1.1-fold (0.06 log units) below, and the stated range covers the measured number.
By their numbers in this assay, from the lowest: compounds 3, 4, 2 and 1 (each within the scatter of the next, the first and the last beyond it).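

Exchanging 3-bromo-2,5-dichlorophenyl for 5-bromo-2,3-dichlorophenyl on the sulfonamide nitrogen gives a 2.0-fold higher number from compound 3 to compound 4 (0.30 log units; within the scatter) in this assay and so leaves the two compounds unseparated, although both aryl groups hold the same atoms, joined differently. The new aryl group also stays within the scatter of the two earlier groups, with a 1.3-fold lower number from compound 2 to compound 4 (0.10 log units; within the scatter) and a 2.0-fold lower number from compound 1 to compound 4 (0.30 log units; within the scatter), so the edge that compound 3 holds over compound 1 and compound 2 is not shared clearly by this rearranged isomer, and compound 3 no longer stands apart from every other compound. Nothing measured here bears on why these halogen arrangements read as they do.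

The aryl groups shown carry only halogens and, in one case, a methyl group. On these data alone, how this position would respond to an amine, a carboxylic acid or a nitrile on that ring remains open.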